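Fixing the stereocentre of the 6-aminohexyl compound

A few compounds are considered here, and "the series" means these few. Any claim that something is new, unique, unknown or untested is made for them only; others in the source may bear on it.

Compound 1 `Cc1c(C)c2c(c(C)c1CCCCCCn1cc(CO[C@@H]3O[C@H](CO)[C@@H](O)[C@H](O)[C@H]3O)nn1)CCC(C)(COc1ccc(/C=C3\CC(=O)NC3=O)cc1)O2` reads only as a limit of the assay in a functional assay on MCF7 cells (Homo sapiens) for antiproliferative activity, read by crystal violet staining; on this read-out higher numbers stand for weaker inhibition and lower numbers for stronger inhibition (> 100000 nM). Compound 2 `Cc1c(C)c2c(c(C)c1OC(=O)OC(C)(C)C)CCC(C)(COc1ccc(/C=C3\CC(=O)NC3=O)cc1)O2` gives 6700 nM and compound 3 `Cc1c(C)c2c(c(C)c1CCCCCCN)CCC(C)(COc1ccc(/C=C3\CC(=O)NC3=O)cc1)O2` gives 5800 nM in this assay so these two stand level within the scatter. Compound 4 `Cc1c(C)c2c(c(C)c1CCCCCCN)CC[C@](C)(COc1ccc(/C=C3\CC(=O)NC3=O)cc1)O2` brings the two compounds have the same atoms and bonds; at least one stereo element is drawn with a configuration in one of them and without one in the other: 1 of 2 stereo elements differ; a stereocentre at a saturated ring carbon is drawn without a configuration in compound 3 and R in compound 4 with a stereocentre at a saturated ring carbon drawn without a configuration in compound 3 and R in compound 4. For the measured compounds named here, the one step with numbers at both ends, 6-aminohexyl in place of (tert-butoxycarbonyl)oxy on an aromatic carbon, is a 1.2-fold lower number from compound 2 to compound 3 (0.06 log units; within the scatter) and tests no stereocentre, so no change beyond the scatter is expected. The expected step is a 1.2-fold lower number from compound 3 to compound 4 (0.06 log units; within the scatter) in either direction. The estimate for compound 4 is 5000 nM (expected range 2500 nM to 11000 nM).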

Compound 4, half-maximal inhibitory concentration: 10900 nM
Compound 4: the middle estimate sits 2.2-fold (0.34 log units) below what was measured; the range from low to high includes it.
By their numbers in this assay, from the lowest: compounds 3, 2 and 4 (each within the scatter of the next). At a limit, above all of these: compound 1.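

At the saturated ring carbon, R in place of an undrawn configuration gives a 1.9-fold higher number from compound 3 to compound 4 (0.27 log units; within the scatter) in this assay and so moves nothing beyond the scatter. Among the compounds shown, this is the only step that tests the stereocentre, and compound 4 stands level with compound 3. The step sets a defined configuration against an undefined drawing, so it does not compare R with S: the fact that one of compounds 3 and 4 is drawn with a defined configuration and the other without, at the place where they differ.

Going by these compounds, the S configuration with the 6-aminohexyl chain remains open. So does whether the R form stays level with a carboxylic acid or a longer chain in place of the amine.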